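A few compounds are considered here, and "the series" means these few. Any claim that something is new, unique, unknown or untested is made for them only; others in the source may bear on it.

Three compounds share a core in which a small heterocycle is linked through a triple bond to a six-membered aromatic ring. Compound 1 `Cc1nc(C#Cc2ccc(F)cn2)cs1` carries a fluoro group on that ring, compound 2 `Cc1nc(C#Cc2cncc(Br)c2)cs1` a bromo group, and compound 3 `Cc1nc(C#Cc2cnccn2)cs1` has a second ring nitrogen instead. In a functional assay on CHO cells for agonist activity at metabotropic glutamate receptor 5 (Homo sapiens), read by inositol phosphate accumulation (on this read-out lower numbers stand for stronger inhibition and higher numbers for weaker inhibition), compound 1 gives 1090 nM, compound 2 gives 60 nM, and compound 3 gives 1830 nM. Compound 2 therefore shows the lowest number of the three, and both other compounds lie beyond the scatter from it, so compound 2 is the strongest of this set.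

Compound 4 `Cc1nc(C#Cc2cncc(C#CCO)c2)cs1` is not yet measured. It differs from compound 2 by 3-hydroxyprop-1-yn-1-yl in place of bromo on an aromatic carbon, which puts a 3-hydroxyprop-1-yn-1-yl group on an aromatic carbon of a six-membered aromatic ring with 1 nitrogen, two atoms from the ring nitrogen, in place of bromo. Within the data shown here, no measured pair here shows such a change, so the size of the step is uncertain. The expectation is a modest move towards a higher number, from compound 2 to compound 4 a 4.2-fold higher number from compound 2 to compound 4 (0.62 log units; beyond the scatter), possibly beyond the scatter. For compound 4 the estimate in this assay is 250 nM, within a range from 50 nM to 1500 nM.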

Compound 4, half-maximal inhibitory concentration: 68.6 nM
Compound 4: middle estimate off by 3.6-fold (0.56 log units), on the high side; measured number inside the range.
By their numbers in this assay, from the lowest: compounds 2 and 4 (each within the scatter of the next); then compounds 1 and 3 (each within the scatter of the next).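

In this assay, 3-hydroxyprop-1-yn-1-yl in place of bromo gives a 1.1-fold higher number from compound 2 to compound 4 (0.06 log units; within the scatter). Among these compounds, this position, two atoms from the ring nitrogen, can therefore take a group of 4 heavy atoms with 1 hydrogen-bond donor and 1 hydrogen-bond acceptor in place of a single bromine, with no difference beyond the scatter, something the earlier compounds could not show because no two of them differed in only one place. Nothing available explains why these two groups give such similar numbers.

On these data alone, it remains open which part of the new group matters, the triple bond or the terminal hydroxyl. A saturated 3-hydroxypropyl chain, a terminal amine or a carboxylic acid in place of the hydroxyl, or a longer chain at this position would each help to separate these features.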